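The source may report more compounds than this note shows. Statements on the series, on what has been measured and on what is new or still open speak of the compounds shown alone.

Series notes: three saccharin-derived amines measured in an assay on HEK293 cells for displacement of a labelled ligand from 5-hydroxytryptamine receptor 6 (Homo sapiens) (a lower number here means a stronger inhibitor, a higher number a weaker inhibitor), so far. Compound 1 `COc1ccccc1N1CCN(CCCCCCN2C(=O)c3ccccc3S2(=O)=O)CC1` gives 779 nM. Compound 2 `O=C1c2ccccc2S(=O)(=O)N1CCCCCN1CCN(c2ncccn2)CC1` gives 7100 nM. Compound 3 `COc1ccccc1N1CCN(Cc2ccc(CN3C(=O)c4ccccc4S3(=O)=O)cc2)CC1` gives 10100 nM. Compound 2 stands second highest of the three numbers: its value sits within the scatter of the value of compound 3, so no order between those two can be read, while compound 1 lies beyond the scatter below both of them with the lowest number of the set. Within the data shown here, no two of the measured compounds differ in only one place, so no single-point step has been recorded; compound 1 and compound 2 differ in both the chain and the aryl group on the ring nitrogen.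

Compound 4 `COc1ccccc1N1CCN(CCCCCN2C(=O)c3ccccc3S2(=O)=O)CC1` has not yet been measured. It differs from compound 2 in one place: 2-methoxyphenyl in place of pyrimidin-2-yl on an amine nitrogen in a ring. Compound 4 carries the same 2-methoxyphenyl group as compound 1 on the same chain length as compound 2, so the expectation rests on compound 1 at 779 nM and compound 2 at 7100 nM. A step from compound 2 to compound 4 toward a lower number, beyond the scatter, is expected, estimated as a 5.9-fold lower number from compound 2 to compound 4 (0.77 log units; beyond the scatter). For compound 4 the estimated value is 1200 nM, with a range from 400 nM to 4000 nM.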

Compound 4, inhibition constant: 1990 nM
Estimate against measurement, compound 4: 1.7-fold (0.22 log units) below; low and high end bracket the measured number.
By their numbers in this assay, from the lowest: compound 1; then compound 4; then compounds 2 and 3 (each within the scatter of the next).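

With the chain held as in compound 2, 2-methoxyphenyl in place of pyrimidin-2-yl on the amine nitrogen in the ring gives a 3.6-fold lower number from compound 2 to compound 4 (0.55 log units; beyond the scatter) in this assay. Among these compounds, this is the first single-place step, and it shows that the group at this position can by itself move the number beyond the scatter, something the earlier compounds, which differed in more than one place, could not separate from the chain. The change swaps a six-membered aromatic ring with 2 hetero atoms for one of carbon only and adds a methoxy group, and nothing recorded for the series connects the size of the step to any one of these differences.

A plain phenyl or a pyridin-2-yl group at the same place would help separate the contribution of the methoxy group from that of the ring nitrogens. On these data alone, whether the step holds on a longer chain stays open, as pyrimidin-2-yl appears here on a single chain length and one step gives no trend.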